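Extending the Ether Chain with a Terminal Alkyne

The source may report more compounds than this note shows. Statements on the series, on what has been measured and on what is new or still open speak of the compounds shown alone.

Compound 1 `C=CCc1cc(C(C)=O)c(O)cc1OCC#N`: 20%
Compound 2 `C=CCc1cc(C(C)=O)c(O)cc1OCCCCC`: 60%

In an assay on isolated protein for inhibition of leukotriene B4 receptor 1 (Homo sapiens), tested at 10 uM (on this read-out lower numbers stand for less inhibition and higher numbers for more inhibition at the one concentration tested (going by the name of the read-out)), compound 2 stands highest of the two measured compounds; compound 1 sits a number 40 percentage points higher from compound 1 to compound 2 (beyond the scatter) behind it. Compound 3 `C#CCCCCOc1cc(O)c(C(C)=O)cc1CC=C` is not yet measured; its change from compound 2 is ethynyl in place of methyl on a saturated chain carbon, four bonds along the chain from an oxygen on an aromatic ring. Going by the values given here, no measured step tests exactly this change. Among the compounds with values here, the only measured step, a number 40 percentage points higher from compound 1 to compound 2 (beyond the scatter), was large, showing the chain on this oxygen matters. The present change is smaller and keeps the chain, so for compound 3 a step of a number 2 percentage points higher from compound 2 to compound 3 (within the scatter) is expected, within the scatter. Compound 3 is estimated at 62%, between 40% and 80%.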

Compound 3, a percentage reported as inhibition, at one concentration (the size of the read-out at that concentration, not a potency): 74%
Estimate against measurement, compound 3: 12 percentage points below; the measured number falls inside the stated range.
By their numbers in this assay, from the lowest: compound 1; then compound 2; then compound 3.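

Changing only the far end of the chain still counts: the step of a number 14 percentage points higher from compound 2 to compound 3 (beyond the scatter) comes from ethynyl in place of methyl, four bonds along the chain from an oxygen on an aromatic ring. In this assay the full exchange of pent-4-yn-1-yl for cyano gives a number 54 percentage points higher from compound 1 to compound 3 (beyond the scatter) on the same oxygen, the widest gap seen so far. Nothing measured here explains why this chain end gives more inhibition. The compounds shown leave open whether the triple bond matters or only the added carbon, which a saturated hexyl chain would help separate. As far as these compounds go, how an amine at the chain end would behave also remains open.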